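Swapping the Ring on the Sulfur: Compound 3 Expected

A few compounds are considered here, and "the series" means these few. Any claim that something is new, unique, unknown or untested is made for them only; others in the source may bear on it.

Compound 1 `Cc1ccc(-c2cs/c(=N/NC(=O)CSc3nnnn3C)n2-c2ccccc2)cc1`: 68.8%
Compound 2 `Cc1ccc(-c2cs/c(=N/NC(=O)CSc3ncccn3)n2-c2ccccc2)cc1`: 83%

In a functional assay on C6 cells (Rattus norvegicus) for cytotoxicity, read by MTT assay, with a stated time of 24 h, tested at 12 ug/mL (on this read-out higher numbers stand for a weaker effect at the one concentration tested and lower numbers for a stronger effect), compound 2 gives 83%, the higher of the two numbers; compound 1 sits lower, a step of a number 14.2 percentage points higher from compound 1 to compound 2 (beyond the scatter). Compound 3 `Cc1ccc(-c2cs/c(=N/NC(=O)CSc3nnc(C)s3)n2-c2ccccc2)cc1` carries the change (5-methyl-1,3,4-thiadiazol-2-yl in place of pyrimidin-2-yl on a sulfur). Among the compounds with values here, the only measured step concerns a different entering ring, so it bears on this change only loosely, showing that the ring on that sulfur can shift the read-out by a modest amount. A small downward step, a number 8 percentage points lower from compound 2 to compound 3 (within the scatter), is therefore expected. Compound 3 is estimated at 75%, with a range from 60% to 90%.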

Compound 3, a percentage reported as activity, at one concentration (the size of the read-out at that concentration, not a potency): 58.3%
The estimate for compound 3 lay 16.7 percentage points above the measured number, outside the stated range (below it).
By their numbers in this assay, from the lowest: compound 3; then compound 1; then compound 2.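

Putting 5-methyl-1,3,4-thiadiazol-2-yl in place of pyrimidin-2-yl gives a number 24.7 percentage points lower from compound 2 to compound 3 (beyond the scatter) in this assay, which means a stronger effect at the one concentration tested. It also outperforms the other five-membered ring, with a number 10.5 percentage points lower from compound 1 to compound 3 (beyond the scatter) on the same read-out, so compound 3 is the strongest of the three and ring size alone does not settle the outcome. Nothing available explains why this ring does best. From the compounds shown here alone, whether a phenyl ring or a simple longer chain on this sulfur would match compound 3 remains open. Going by these compounds, since only one concentration is reported, whether compound 3 would also give a stronger effect at other concentrations remains open.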